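Indole amides on the arylpiperazine series: compound 4

The source may hold more compounds than are shown below. What is called first, only, known or untested is meant among the compounds shown, and "the series" means these compounds.

Among the measured compounds shown here, compound 3 `COc1ccccc1N1CCN(CCCNC(=O)c2cc3ccc(Br)cc3[nH]2)CC1` gives 15.1 nM in an assay on isolated protein (thoracic aorta, strain Sprague-Dawley) for antagonist activity at Alpha-1D adrenergic receptor (Rattus norvegicus), with a stated time of 20 min (a lower number here means tighter binding, a higher number weaker binding), the highest of the three numbers measured so far. Compound 1 `COc1ccccc1N1CCN(CCCNC(=O)Cc2c[nH]c3ccccc23)CC1` gives 5.25 nM in this assay and compound 2 `COc1ccccc1N1CCN(CCCNC(=O)CCCc2c[nH]c3ccccc23)CC1` gives 5.13 nM; these two values lie within the scatter of each other. For the measured compounds named here, the one measured step that reaches compound 3 is a 2.9-fold higher number from compound 1 to compound 3 (0.46 log units; beyond the scatter).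

Compound 4 `COc1ccccc1N1CCN(CCCNC(=O)c2cn(C)c3ccccc23)CC1` has not been measured. It differs from compound 3 in that (1-methyl-1H-indol-3-yl in place of 6-bromo-1H-indol-2-yl on a carbonyl carbon). Going by the values given here, no measured step covers this change. Among the compounds with values here, the only guidance is that compound 1, which also carries the indole through the ring's 3-position, sits lower than compound 3 by a 2.9-fold higher number from compound 1 to compound 3 (0.46 log units; beyond the scatter), so the return to that attachment is expected to give back part of that difference, though the missing methylene and the added methyl are untested. Compound 4 is therefore estimated at 7 nM in this assay, in a range from 2.5 nM to 25 nM. The estimated step of a 2.2-fold lower number from compound 3 to compound 4 (0.33 log units; beyond the scatter) is modest and may fall within the scatter.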

Compound 4, dissociation constant: 5.5 nM
Beside the measured number, compound 4's estimate is 1.3-fold (0.10 log units) above it; low and high end bracket the measured number.
By their numbers in this assay, from the lowest: compounds 2, 1 and 4 (each within the scatter of the next); then compound 3.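

On the carbonyl carbon, 1-methyl-1H-indol-3-yl in place of 6-bromo-1H-indol-2-yl gives a 2.7-fold lower number from compound 3 to compound 4 (0.44 log units; beyond the scatter) in this assay, so a group attached directly to the carbonyl carbon does not by itself carry the higher number seen for compound 3. Replacing (1H-indol-3-yl)methyl with 1-methyl-1H-indol-3-yl gives a 1.0-fold higher number from compound 1 to compound 4 (0.02 log units; within the scatter), so these two compounds cannot be told apart in this assay. Nothing available explains either step.

The bromine, the point of attachment and the methyl all change together in the first step, so that step cannot be assigned to any one of them. A plain 1H-indol-3-yl on the carbonyl carbon, or a chlorine in place of the bromine, would be needed to begin separating these contributions.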